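Shifting the nitro group on the saturated ring carbon

This account rests on a few compounds, and the source may have more. Where it says the series, first, only, none or still open, it means among the compounds named here.

Measured so far in a functional assay on the whole organism (strain albino) for inhibition, with Rattus norvegicus as the target, read by paw edema, with stated times of 1 h and 3 h, at a dose of 25 mg/kg by the oral route; on this read-out lower numbers stand for less inhibition and higher numbers for more inhibition at the one dose given (going by the name of the read-out):
compound 1, `CC1=C(C(=O)Nc2ccc(F)cc2)C(c2ccc([N+](=O)[O-])cc2)n2c(s/c(=C/c3ccccc3Cl)c2=O)=N1`, gives 19%
compound 2, `CC1=C(C(=O)Nc2ccc(F)cc2)C(c2ccc([N+](=O)[O-])cc2)n2c(s/c(=C/c3ccccc3)c2=O)=N1`, gives 7%

Compound 1 stands highest of the two numbers; its nearest neighbour is compound 2, and the step of a number 12 percentage points lower from compound 1 to compound 2 (beyond the scatter) lies beyond the scatter. That step concerns hydrogen in place of chloro on an aromatic carbon and leaves the rest of the shared core as it is.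

Compound 3, `CC1=C(C(=O)Nc2ccc(F)cc2)C(c2ccccc2[N+](=O)[O-])n2c(s/c(=C/c3ccccc3Cl)c2=O)=N1`, is not yet measured. Its difference from compound 1 is 2-nitrophenyl in place of 4-nitrophenyl on a saturated ring carbon. Among the measured compounds shown here, the two compounds have the same atoms, joined differently, and the place of the change is a saturated ring carbon of the shared core, not the aromatic carbon touched in the one measured step. For the measured compounds named here, no measured step bears on this change, so the known data give no direction for it, and the expectation is a step within the scatter. The expected step is a number 4 percentage points lower from compound 1 to compound 3 (within the scatter), with a modest lean downward because compound 1 gives 19% and nothing in the series suggests a higher number. Compound 3 is expected at 15%, between 3% and 30%.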

Compound 3, a percentage reported as inhibition, in the whole organism at one dose (the size of the read-out at that dose, not a potency): 12%
Beside the measured number, compound 3's estimate is 3 percentage points above it; the measured number falls inside the stated range.
By their numbers in this assay, from the lowest: compounds 2, 3 and 1 (each within the scatter of the next, the first and the last beyond it).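

In this assay, among the compounds shown here, the first reading at the saturated ring carbon is a number 7 percentage points lower from compound 1 to compound 3 (within the scatter); at this one dose, 2-nitrophenyl in place of 4-nitrophenyl does not separate the two compounds. For the compounds shown here, the only earlier step (a number 12 percentage points lower from compound 1 to compound 2 (beyond the scatter)) concerned chloro on an aromatic carbon, so this position now has a reading of its own, and moving the nitro group around the phenyl ring gives no change that can be told from the scatter. Nothing at hand offers an explanation for this result.

Open, going by these compounds, is whether the group on this carbon matters at all once the nitro group is replaced: an amino group, a carboxylic acid, a methoxy group or a plain phenyl ring at this place could show whether the read-out responds here beyond the scatter. Also open, on these data alone, is whether 3-nitrophenyl reads like the two isomers in hand, and whether the step for hydrogen in place of chloro holds with 2-nitrophenyl on the shared core, since that step is so far known only with 4-nitrophenyl.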